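Swapping Methoxy for Methyl on a Tolerated Compound

A few compounds are considered here, and "the series" means these few. Any claim that something is new, unique, unknown or untested is made for them only; others in the source may bear on it.

In a functional assay on C8166 cells (Homo sapiens) for cytotoxicity (a higher number here means that more compound is tolerated, a lower number that less compound is tolerated), compound 2 `COc1ccc2nc(C=C(C)C)n(OCC=C(C)C)c2c1` gives 80 uM and compound 1 `CC(C)=CCOn1c(C=C(C)C)nc2c(C)cccc21` gives 50 uM here, so the two stand within the usual scatter of each other. Compound 3 `CC(C)=CCOn1c(C=C(C)C)nc2ccc(C)cc21` differs from compound 2 in one place: methyl in place of methoxy on an aromatic carbon with methyl in place of methoxy on an aromatic carbon. For the measured compounds named here, no measured pair shows this swap, so the size of the change can only be estimated. In this assay the expected result is no step beyond the scatter, with a 1.3-fold lower number from compound 2 to compound 3 (0.12 log units; within the scatter) as the estimated small step. Compound 3 is expected at 60 uM as a middle value, with 30 uM to 120 uM as its range.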

Compound 3, half-maximal toxic concentration: 50 uM
The estimate for compound 3 lay 1.2-fold (0.08 log units) above the measured number; low and high end bracket the measured number.
By their numbers in this assay, from the lowest: compounds 1, 3 and 2 (each within the scatter of the next).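

For the compounds shown here, this is the first measured swap at this position. In this assay methyl in place of methoxy on this aromatic carbon gives a 1.6-fold lower number from compound 2 to compound 3 (0.20 log units; within the scatter) and so makes no difference beyond the scatter. Removing the oxygen of the methoxy group, and with it a hydrogen-bond acceptor, therefore leaves the tolerated concentration effectively unchanged in this pair. Nothing measured here explains this result. The compounds shown leave open whether an amine, a carboxylic acid or a longer chain on this same carbon would be tolerated alike.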